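Adding a Fluorosulfonyl Group to a Potent Reductase Inhibitor

The source may report more compounds than this note shows. Statements on the series, on what has been measured and on what is new or still open speak of the compounds shown alone.

Measured compounds:
compound 1 `CC1(C)N=C(N)N=C(N)N1c1ccc(CCCCc2ccccc2)c(Cl)c1`: 7.92
compound 2 `CC1(C)N=C(N)N=C(N)N1c1ccc(OCCCNC(=O)Nc2ccc(S(=O)(=O)F)cc2)c(Cl)c1`: 7.68
compound 3 `CC1(C)N=C(N)N=C(N)N1c1ccc(CCC(=O)Nc2ccc(S(=O)(=O)F)cc2)c(Cl)c1`: 7.62

All three compounds share the same core and were tested in an assay on isolated protein for inhibition of Dihydrofolate reductase (Mus musculus); on this read-out lower numbers stand for lower potency and higher numbers for higher potency (the scale is a negative logarithm). Compound 1 has the highest of the three numbers, but the margin is small: compound 2 lies closest, lower by an amount within the usual scatter, and compound 3, the furthest, is also lower by an amount within the scatter. The three values therefore cannot be ranked with confidence.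

Compound 4 `CC1(C)N=C(N)N=C(N)N1c1ccc(CCCCc2ccccc2S(=O)(=O)F)c(Cl)c1` differs from compound 1 in a single way: fluorosulfonyl in place of hydrogen on an aromatic carbon, placed ortho to a large group on the six-membered aromatic ring of carbon only. Among the measured compounds shown here, no pair of measured compounds differs in exactly this way, so no measured step can be copied. Still, compound 2 at 7.68 and compound 3 at 7.62 both carry a fluorosulfonyl group, and both sit within the scatter of compound 1. On that basis the step is expected to be small, with no direction beyond the scatter, which in this estimate amounts to a number 0.02 log units lower from compound 1 to compound 4 (within the scatter). Compound 4 is therefore estimated to give 7.9 in this assay, most likely between 7.3 and 8.5.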

Compound 4, logarithm of the reciprocal of the active concentration, log(1/C): 7.77
Compound 4: middle estimate off by 0.13 log units, on the high side, and the stated range covers the measured number.
By their numbers in this assay, from the lowest: compounds 3, 2, 4 and 1 (each within the scatter of the next).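

Fluorosulfonyl in place of hydrogen on an aromatic carbon, ortho to a large group, gives a number 0.15 log units lower from compound 1 to compound 4 (within the scatter) in this assay as a clean single change. Compounds 2 and 3 also carry fluorosulfonyl, but they differ from compound 1 in more than one place, so they could not show what the group does by itself. Compound 4 does show this: at this place on the six-membered aromatic ring of carbon only, adding the group's 4 heavy atoms leaves the read-out within the usual scatter of repeated measurements, and nothing given here offers a measured reason for that outcome.

As far as these compounds go, what an amine or a carboxylic acid would do at this same place stays open, so it is unclear whether this position would give a similar reading with other groups. Also open, from the compounds shown here alone, is whether fluorosulfonyl would give a similar reading on another carbon of this ring, or with a longer chain joining this ring to the shared core.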